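Amine replaces amide on the piperidine: distribution expectation

This account rests on a few compounds, and the source may have more. Where it says the series, first, only, none or still open, it means among the compounds named here.

Compound 1 `CCCCCOC(=O)N1CCN(C(=O)[C@H](CCC(=O)O)NC(=O)c2cc(N3CCC(C(=O)N(CC)CC)CC3)nc(-c3ccccc3)n2)CC1`: 0.21 L/kg
Compound 2 `CCCCCOC(=O)N1CCN(C(=O)[C@H](CCC(=O)O)NC(=O)c2cc(N3CCC(C(=O)NCC)CC3)nc(-c3ccccc3)n2)CC1`: 0.2 L/kg
Compound 3 `CCCCCOC(=O)N1CCN(C(=O)[C@H](CCC(=O)O)NC(=O)c2nc(-c3ccccc3)cc(N3CCC(CN)CC3)n2)CC1`: 0.28 L/kg

In an in vivo ADME assay on the whole organism (strain Sprague-Dawley) for pharmacokinetics, with Rattus norvegicus as the target (on this read-out lower numbers stand for narrower distribution and higher numbers for wider distribution into tissues), compound 2 gives the lowest of the three numbers, though compound 1 and compound 3 sit within the scatter of it. Among the measured compounds shown here, the one measured step that touches the same position, a 1.1-fold lower number from compound 1 to compound 2 (0.02 log units; within the scatter), was within the scatter. For the measured compounds named here, compound 4 `CCCCCOC(=O)N1CCN(C(=O)[C@H](CCC(=O)O)NC(=O)c2cc(N3CCC(CNC)CC3)nc(-c3ccccc3)n2)CC1` differs from compound 2 by (methylamino)methyl in place of ethylcarbamoyl on a saturated ring carbon; no step covers this change directly, but compound 3, which carries an aminomethyl at that ring carbon, shows a number close to that of compound 2. The expected step is therefore small, a 1.5-fold higher number from compound 2 to compound 4 (0.18 log units; within the scatter), and compound 4 is estimated at 0.3 L/kg with a range from 0.15 L/kg to 0.6 L/kg.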

Compound 4, volume of distribution at steady state: 2 L/kg
Compound 4: the middle estimate sits 6.7-fold (0.82 log units) below what was measured; measured number outside the range, above it.
By their numbers in this assay, from the lowest: compounds 2, 1 and 3 (each within the scatter of the next); then compound 4.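

In this assay, the saturated ring carbon turns out to matter. With (methylamino)methyl in place of the carbamoyl groups there is a 10-fold higher number from compound 2 to compound 4 (1.00 log units; beyond the scatter) and a 9.5-fold higher number from compound 1 to compound 4 (0.98 log units; beyond the scatter), both beyond the scatter, whereas changing the substituent on the amide nitrogen gave only a 1.1-fold lower number from compound 1 to compound 2 (0.02 log units; within the scatter), within the scatter. No measurement at hand accounts for the rise.

As far as these compounds go, whether the rise follows the amine nitrogen itself remains open. A hydroxymethyl or a (dimethylamino)methyl on that ring carbon of the same core would bear on this, as would a longer chain carrying the amine.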